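Solubility of a furanylmethylamine series: aryl in place of alkyl

The source may hold more compounds than are shown below. What is called first, only, known or untested is meant among the compounds shown, and "the series" means these compounds.

Compound 1 `CC(C)Cc1ccc2c(NCCCNCc3ccco3)ccnc2c1` is the reference for this comparison. Within the data shown here, in a physicochemical assay for solubility, with a stated time of 18 h, at pH 7.4 (on this read-out lower numbers stand for lower solubility and higher numbers for higher solubility), compound 1 gives 4200 nM, the lowest of the two numbers so far; its nearest neighbour is compound 2 `c1ccc(Oc2ccc3c(NCCCNCc4ccco4)ccnc3c2)cc1`, which in this assay gives 14500 nM. Among the measured compounds shown here, the one measured step, a 3.5-fold higher number from compound 1 to compound 2 (0.54 log units; beyond the scatter), is the only one that bears on the present question, since it also exchanges an alkyl group for an aryl-bearing group on the shared core.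

Compound 3 `FC(F)(F)c1cccc(Cc2ccc3c(NCCCNCc4ccco4)ccnc3c2)c1` differs from compound 1 by 3-(trifluoromethyl)phenyl in place of isopropyl on a saturated chain carbon bound to an aromatic carbon. For the measured compounds named here, the measured step puts an aryl group in place of an alkyl group and the number rose; the change here instead enlarges the substituent and adds a trifluoromethyl group, with no measured precedent for it. The expectation is therefore a small step for compound 3, probably downward, a 1.4-fold lower number from compound 1 to compound 3 (0.15 log units; within the scatter), and uncertain. Compound 3 is estimated at 3000 nM, with a range of 800 nM to 11000 nM.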

Compound 3, solubility: 4200 nM
The estimate for compound 3 lay 1.4-fold (0.15 log units) below the measured number; the measured number falls inside the stated range.
By their numbers in this assay, from the lowest: compounds 1 and 3 (each within the scatter of the next); then compound 2.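

In this assay the exchange of isopropyl for 3-(trifluoromethyl)phenyl on a saturated chain carbon bound to an aromatic carbon gives no change at the digits printed from compound 1 to compound 3 (within the scatter), even though the entering group has 10 heavy atoms against 3. An aromatic ring in the substituent therefore does not go with a higher number in every case: a 3.5-fold higher number from compound 1 to compound 2 (0.54 log units; beyond the scatter) holds for the phenoxy exchange alone, and compound 3 goes against any wider pattern. No available evidence bears on this result.

The compounds shown leave open whether a phenyl ring without trifluoromethyl would behave as 3-(trifluoromethyl)phenyl does at this place. They also leave open whether a morpholine or a carboxylic acid on the same saturated chain carbon would move the number beyond the scatter.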